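The source may hold more compounds than are shown below. What is called first, only, known or untested is meant among the compounds shown, and "the series" means these compounds.

Measured compounds:
Compound 1 `O=c1cc(-c2ccccc2)oc2cc(N3COc4c(cccc4[N+](=O)[O-])C3)ccc12` — "not active" (no number reported) in a functional assay on MCF7 cells (Homo sapiens) for inhibition, read by MTT assay, with a stated time of 48 h; on this read-out higher numbers stand for weaker inhibition and lower numbers for stronger inhibition.
Compound 2 `Cc1cccc2c1OCN(c1ccc3c(=O)cc(-c4ccccc4)oc3c1)C2` — 14900 nM.

Compound 2 thus holds the only number shown in this assay, while compound 1 stands beside it without one. Compound 3 `O=c1cc(-c2ccccc2)oc2cc(N3COc4ccccc4C3)ccc12` differs from compound 2 by hydrogen in place of methyl on an aromatic carbon. Going by the values given here, no step between measured compounds is known here, so the expectation for a 1.3-fold higher number from compound 2 to compound 3 (0.13 log units; within the scatter) is a shift of no size beyond the scatter, leaning if anything toward weaker inhibition. Compound 3 is therefore estimated at 20000 nM, with a range from 7000 nM to 60000 nM.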

Compound 3, half-maximal inhibitory concentration: "not active" (no number reported)
No number was reported for compound 3, and the estimate cannot be compared.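

In this assay, going by these compounds alone, compound 3 gives "not active" (no number reported) without a number, so no step from compound 2 to it can be read. How far the methyl of compound 2 matters for inhibition stays open, and nothing shown here bears on the result.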